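Urea-to-amide step in a pyrazole-biaryl series, melanoma cells

A few compounds are considered here, and "the series" means these few. Any claim that something is new, unique, unknown or untested is made for them only; others in the source may bear on it.

Measured compounds:
compound 1 `COc1cc(Cl)cc(-c2nn(-c3cccc(NC(=O)Nc4ccc(Cl)c(Cl)c4)c3)cc2-c2ccncc2)c1` — 95%
compound 2 `COc1cc(Cl)cc(-c2nn(-c3cccc(NC(=O)Nc4cccc(C(F)(F)F)c4)c3)cc2-c2ccncc2)c1` — 96%

In a functional assay on UACC-62 cells (Homo sapiens) for inhibition, read by sulforhodamine B assay, with a stated time of 48 h, tested at 0.01 uM (a lower number here means a stronger effect, a higher number a weaker effect of the compound at the concentration tested), compound 1 gives 95% and compound 2 gives 96%; both numbers sit near the top of the scale, so neither compound shows much effect at this concentration. Compound 2 stands at one end of the two values, separated from compound 1 by a number 1 percentage points higher from compound 1 to compound 2 (within the scatter), so the two cannot be told apart.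

Compound 3 `COc1cc(Cl)cc(-c2nn(-c3cccc(NC(=O)c4cccc(C(F)(F)F)c4)c3)cc2-c2ccncc2)c1` differs from compound 2 by 3-(trifluoromethyl)phenyl in place of (3-(trifluoromethyl)phenyl)amino on a carbonyl carbon. Among the measured compounds shown here, the only measured step, an exchange of one aryl group on the amide-type nitrogen, was a number 1 percentage points higher from compound 1 to compound 2 (within the scatter) and does not touch the carbonyl carbon, so no measured step bears directly on this change. For the measured compounds named here, with both parents near the top of the scale and no relevant precedent, the step from compound 2 to compound 3 is expected to be a number 1 percentage points lower from compound 2 to compound 3 (within the scatter), none beyond the scatter. Compound 3 is therefore estimated at 95% in this assay, with a range from 84% to 102%.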

Compound 3, a percentage reported as activity, at one concentration (the size of the read-out at that concentration, not a potency): 98%
Compound 3: the middle estimate sits 3 percentage points below what was measured; the range from low to high includes it.
By their numbers in this assay, from the lowest: compounds 1, 2 and 3 (each within the scatter of the next).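

In this assay, 3-(trifluoromethyl)phenyl in place of (3-(trifluoromethyl)phenyl)amino on the carbonyl carbon gives a number 2 percentage points higher from compound 2 to compound 3 (within the scatter), and the same group in place of (3,4-dichlorophenyl)amino gives a number 3 percentage points higher from compound 1 to compound 3 (within the scatter). At this single concentration, therefore, the urea and the amide cannot be told apart, although the amino nitrogen and its hydrogen-bond donor are gone from this position. With all three numbers near the top of the scale, this shows only that little effect appears at this concentration for either link, and no evidence bears on the result.

From the compounds shown here alone, whether the two links would separate at a concentration where the effect is larger remains open. Also open, going by these compounds, is what a methylene group in place of the amino nitrogen, or a carboxylic acid on the phenyl group, would give here.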